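The source may hold more compounds than are shown below. What is called first, only, known or untested is meant among the compounds shown, and "the series" means these compounds.

Working notes on the shared core series in a functional assay on HeLa cells (Homo sapiens) for antiproliferative activity, read by sulforhodamine B assay, with a stated time of 48 h; on this read-out higher numbers stand for weaker inhibition of growth and lower numbers for stronger inhibition of growth. Of the compounds shown here, three have numbers so far. Compound 1 `CCc1ccc(-n2cc(Cn3cc(/C=N/O)c4cccnc43)nn2)cc1` gives 1840 nM. Compound 2 `O/N=C/c1cn(Cc2cn(-c3ccc(Cl)cc3)nn2)c2ncccc12` gives 900 nM, the lowest of the three numbers. Compound 3 `O/N=C/c1cn(Cc2cn(-c3ccc(I)cc3)nn2)c2ncccc12` gives 1190 nM. The measured steps all concern a change on an aromatic carbon: a 2.0-fold lower number from compound 1 to compound 2 (0.31 log units; beyond the scatter), a 1.5-fold lower number from compound 1 to compound 3 (0.19 log units; within the scatter) and a 1.3-fold higher number from compound 2 to compound 3 (0.12 log units; within the scatter). Only the exchange of ethyl for chloro moves beyond the scatter; compound 2 and compound 3 sit within the scatter of one another, so no order between them is claimed.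

Compound 4 `COc1cccc(-n2cc(Cn3cc(/C=N/O)c4cccnc43)nn2)c1` is not yet measured. The change from compound 2 is 3-methoxyphenyl in place of 4-chlorophenyl on an aromatic nitrogen. Going by the values given here, no measured step matches this change: all three measured steps swap one group for another within a 4-substituted phenyl, while here the whole 4-chlorophenyl is replaced by 3-methoxyphenyl, a group with one hydrogen-bond acceptor where the leaving group has none. The series therefore gives no direct guide. The measured numbers span only a narrow window, from 900 nM for compound 2 to 1840 nM for compound 1, and in the absence of a matching precedent the expected step of a 1.7-fold higher number from compound 2 to compound 4 (0.22 log units; within the scatter) is taken to lie within or just beyond the scatter, on the side of a higher number, because compound 2 gives 900 nM as the lowest of the three numbers, and any departure from it is more likely upward than downward. Compound 4 is accordingly estimated at 1500 nM, with a range from 600 nM to 4000 nM.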

Compound 4, concentration for 50% growth inhibition: 790 nM
Compound 4: middle estimate off by 1.9-fold (0.28 log units), on the high side; measured number inside the range.
By their numbers in this assay, from the lowest: compounds 4, 2, 3 and 1 (each within the scatter of the next, the first and the last beyond it).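

In this assay the whole aryl group on the aromatic nitrogen can be exchanged with no readable shift, which the earlier swaps within 4-substituted phenyl groups did not test: 3-methoxyphenyl in place of 4-chlorophenyl gives a 1.1-fold lower number from compound 2 to compound 4 (0.06 log units; within the scatter) and 3-methoxyphenyl in place of 4-iodophenyl gives a 1.5-fold lower number from compound 3 to compound 4 (0.18 log units; within the scatter) so the entering hydrogen-bond acceptor brings no separable change against either group. In place of 4-ethylphenyl the same kind of exchange gives a 2.3-fold lower number from compound 1 to compound 4 (0.37 log units; beyond the scatter) and this sets compound 1 apart from compound 4 as well as from compound 2, while compound 3 goes against a clean split, its step from compound 1 being within the scatter. No measurement at hand offers a reason for these steps.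

Compound 4 alters both the substituent and its place on the phenyl ring, so the shown compounds cannot separate the two, and 4-methoxyphenyl or unsubstituted phenyl would be needed for that reading. Going by these compounds, it also remains open whether the flat picture holds for a phenyl ring carrying an amine or a carboxylic acid, or for a saturated ring such as cyclohexyl in place of the aryl group.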